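The source may hold more compounds than are shown below. What is called first, only, known or untested is meant among the compounds shown, and "the series" means these compounds.

The study follows cytotoxicity in an ADME assay on WI-38 cells (Homo sapiens) for cytotoxicity, read by MTT assay, with a stated time of 72 h; a lower number here means a stronger inhibitor, a higher number a weaker inhibitor. Compound 1 `COc1cc(OC)cc(-c2cccc(NC(=O)CCc3ccc4c(c3)COB4O)c2)c1` gives only a limit there, > 100000 nM. Compound 2 `CC(=O)c1ccc(-c2cccc(NC(=O)CCc3ccc4c(c3)COB4O)c2)cc1` likewise gives only a limit, > 100000 nM. Compound 3 `COc1cc(OC)cc(-c2cccc(NC(=O)CCc3cccc4c3COB4O)c2)c1` also gives only a limit, > 100000 nM. Compound 2 is made from compound 1 by 4-acetylphenyl in place of 3,5-dimethoxyphenyl on an aromatic carbon, and a step that the two limits leave unreadable from compound 1 to compound 2. The two cores differ in that (a group of 10 heavy atoms (7 carbon, 1 boron, 2 oxygen; one five-membered non-aromatic ring with 2 hetero atoms, one six-membered aromatic ring of carbon only) in place of a group of 10 heavy atoms (7 carbon, 1 boron, 2 oxygen; one five-membered non-aromatic ring with 2 hetero atoms, one six-membered aromatic ring of carbon only), on a saturated chain carbon, two bonds along the chain from a carbonyl carbon), and a step that the two limits leave unreadable from compound 1 to compound 3. Compound 4 `CC(=O)c1ccc(-c2cccc(NC(=O)CCc3cccc4c3COB4O)c2)cc1` carries the same change on the core of compound 3: 4-acetylphenyl in place of 3,5-dimethoxyphenyl on an aromatic carbon. Among the compounds with values here, all three measured values sit at the limit of > 100000 nM in this assay, at which 3 of the 3 values shown sit, so no step among them can be read. For compound 4 the step from compound 3 is expected to be a number no higher from compound 3 to compound 4 (the limit leaves the size open), resting on (the limit of > 100000 nM in this assay, at which 3 of the 3 values shown sit). Compound 4 is therefore estimated at 100000 nM, between 50000 nM and 200000 nM, most probably again reported only as a limit.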

Compound 4, half-maximal inhibitory concentration: > 100000 nM
Compound 4: only a limit was reported (the forecaster's own chance of this, stated with the estimate: 85%); the middle value lies on the limit itself.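

Compound 4 gives only a limit, > 100000 nM, so its steps from compound 3 and compound 2 cannot be read: the limit of > 100000 nM in this assay, at which 4 of the 4 values shown sit. The compounds shown leave open whether either change alters the read-out in this assay.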